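This account rests on a few compounds, and the source may have more. Where it says the series, first, only, none or still open, it means among the compounds named here.

Measured so far in a functional assay on HL-60 cells (Homo sapiens) for inhibition, read by MTT assay, with a stated time of 72 h; a lower number here means a stronger inhibitor, a higher number a weaker inhibitor:
- compound 1 `Cc1nc(-c2ccccc2)c(C(=O)N2CCN(c3cccc(C)c3C)CC2)o1`: 35 nM
- compound 2 `Cc1ccc(C)c(N2CCN(C(=O)c3oc(C)nc3-c3ccccc3)CC2)c1`: 31.3 nM
- compound 3 `Cc1nc(-c2ccccc2)c(C(=O)N2CCN(c3ccccc3Cl)CC2)o1`: 124 nM

Compound 3 has the highest number of the three, which makes it the weakest inhibitor measured here. The next compound is compound 4 `CCOc1cccc(N2CCN(C(=O)c3oc(C)nc3-c3ccccc3)CC2)c1`, with 3-ethoxyphenyl in place of 2-chlorophenyl on an amine nitrogen in a ring.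

For the measured compounds named here, no measured compound carries an ethoxy group, so no step tests this group directly. The nearest evidence comes from swaps at the same place. Both a 3.5-fold higher number from compound 1 to compound 3 (0.55 log units; beyond the scatter) and a 4.0-fold higher number from compound 2 to compound 3 (0.60 log units; beyond the scatter) are modest, while a 1.1-fold lower number from compound 1 to compound 2 (0.05 log units; within the scatter) shows that the two dimethylphenyl groups do not separate. Going by the values given here, with only this evidence, a move from the 2-chlorophenyl group toward a lower number in this assay is expected, no larger than those two modest steps, though the direction is uncertain. The estimated change is a 1.8-fold lower number from compound 3 to compound 4 (0.25 log units; within the scatter). For compound 4 the expected value is 70 nM, with an estimated range of 20 nM to 240 nM.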

Compound 4, half-maximal inhibitory concentration: 151 nM
Beside the measured number, compound 4's estimate is 2.2-fold (0.33 log units) below it; the range from low to high includes it.
By their numbers in this assay, from the lowest: compounds 2 and 1 (each within the scatter of the next); then compounds 3 and 4 (each within the scatter of the next).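

In this assay, a swap of the 2-chlorophenyl group for the 3-ethoxyphenyl group adds heavy atoms and a hydrogen-bond acceptor, yet a 1.2-fold higher number from compound 3 to compound 4 (0.09 log units; within the scatter) does not separate the two groups. Both dimethylphenyl compounds stand apart from the new compound, with a 4.8-fold higher number from compound 2 to compound 4 (0.68 log units; beyond the scatter) and a 4.3-fold higher number from compound 1 to compound 4 (0.63 log units; beyond the scatter) showing that a second aryl group besides 2-chlorophenyl sits at higher numbers than these two, and none of the four compounds goes against this split. Nothing measured here bears on why the aryl groups divide in this way.

As far as these compounds go, whether a longer alkoxy chain, or an amine or carboxylic acid on the phenyl ring, would keep the number of compound 4 remains open. The shared core is constant throughout, so its contribution is also unresolved.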